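Adding a methoxy group to a phenylethynyl pyridinone

The source may report more compounds than this note shows. Statements on the series, on what has been measured and on what is new or still open speak of the compounds shown alone.

Of the compounds shown here, two have been measured in a functional assay on HEK293 cells for positive allosteric modulation of metabotropic glutamate receptor 5 (Homo sapiens), read by FLIPR and calcium flux; on this read-out lower numbers stand for an effect already at smaller amounts and higher numbers for an effect only at larger amounts of compound. Compound 1 `CC(C)NC(=O)c1ccc(C#Cc2ccccc2)nc1` is an open-chain amide; in this assay compound 1 gives 62 nM. Compound 2 `O=C1c2ccc(C#Cc3ccccc3)nc2CCN1C1CCCC1` carries a ring-closed lactam in place of that amide; in this assay compound 2 gives 5.9 nM. That puts compound 2 at the lowest of the two numbers, and the gap to compound 1 is well beyond the scatter of repeated measurements, so compound 2 is the more potent of the pair. Within the data shown here, no step between these two is counted here, because they differ in more than one place.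

Compound 3 `COc1cccc(C#Cc2ccc3c(n2)CCN(C2CCCC2)C3=O)c1` keeps the whole core of compound 2 and changes only the far phenyl ring: methoxy in place of hydrogen on an aromatic carbon, on an aromatic carbon of a six-membered aromatic ring of carbon only, meta to a large group. Among the measured compounds shown here, no measured pair shows what this exact change does, so the expectation rests on compound 2 alone. A small group added at that place is expected to leave the number close to where compound 2 stands, with a step of a 1.2-fold lower number from compound 2 to compound 3 (0.07 log units; within the scatter) that is not expected to go beyond the scatter. For compound 3 the estimate in this assay is 5 nM, with a range from 1.5 nM to 20 nM.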

Compound 3, half-maximal effective concentration: 462 nM
Compound 3: the middle estimate sits 92-fold (1.97 log units) below what was measured; the whole stated range lies below it.
By their numbers in this assay, from the lowest: compound 2; then compound 1; then compound 3.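

In this assay, the change from phenyl to 3-methoxyphenyl, with the rest of the molecule left as it is, produces a 78-fold higher number from compound 2 to compound 3 (1.89 log units; beyond the scatter), a large step well beyond the scatter. Compound 1 and compound 2 carry the same unsubstituted phenyl ring, so they could say nothing about how this ring responds to substitution. This pair now shows that the ring is far from indifferent to substitution: adding a methoxy group of only 2 heavy atoms, on an aromatic carbon meta to a large group, is enough to make compound 3 the highest number of the three, although no measurement at hand explains why the number climbs so far.

The compounds shown cannot tell whether this loss belongs to methoxy in particular or to any addition at this place, a question that a fluorine atom, a methyl group or a hydroxyl group on the same ring carbon would help to answer. They also leave open how the same methoxy group would behave on a different carbon of this ring, and whether a longer chain such as ethoxy would push the number higher still.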